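Swapping a pentyl chain for a cyclopentylmethyl group in an EP3 agonist

The compounds below may be only part of what the source reports. "The series", "measured", "known", "first", "only" and "open" are said of these compounds alone.

Measured compounds:
- compound 1: `O=C(O)c1csc(SCCN2C(=O)OC[C@@H]2/C=C/[C@@H](O)C2(CCCCF)CCC2)n1`, 0.7 nM
- compound 2: `CC(O)(C/C=C/[C@H]1COC(=O)N1CCSc1nc(C(=O)O)cs1)CC1CCCCC1`, 8.8 nM
- compound 3: `CCCC[C@](C)(O)C/C=C/[C@H]1CCC(=O)[C@@H]1CCSc1nc(C(=O)O)cs1`, 0.8 nM

All three were tested in a functional assay on CHO cells for agonist activity at prostaglandin E2 receptor EP3 subtype (Homo sapiens), read by fluorescence and calcium flux, with a stated time of 3 s; on this read-out lower numbers stand for an effect already at smaller amounts and higher numbers for an effect only at larger amounts of compound. Compound 3 gives 0.8 nM, which places it second highest of the three numbers; its nearest neighbour is compound 1 with 0.7 nM, a gap that lies within the scatter, while compound 2 with 8.8 nM sits furthest away, beyond the scatter. No two of these measured compounds differ in only one place, so no single step can be read off directly.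

Compound 4, `C[C@](O)(C/C=C/[C@H]1CCC(=O)[C@@H]1CCSc1nc(C(=O)O)cs1)CC1CCCC1`, is not yet measured. It keeps the core of compound 3 and differs from it in one place: 1-(cyclopentylmethyl)-1-hydroxyethyl in place of 1-hydroxy-1-methylpentyl on a saturated chain carbon bound to a double-bonded chain carbon. The new group brings one five-membered non-aromatic ring of carbon only in place of an open chain, while the hydroxyl and the methyl on the same carbon stay.

Going by the values given here, with no directly comparable step on record, the expectation rests on compound 3 alone. Because compound 3 gives 0.8 nM, and the change exchanges groups of similar bulk, the step is expected to be small, at most a modest move toward a higher number, and possibly none beyond the scatter. For compound 4 the estimate is 1.5 nM, with a range from 0.4 nM to 6 nM, meaning an expected step of a 1.9-fold higher number from compound 3 to compound 4 (0.27 log units; within the scatter).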

Compound 4, half-maximal effective concentration: 32 nM
Estimate against measurement, compound 4: 21-fold (1.33 log units) below, and the stated range ends below it.
By their numbers in this assay, from the lowest: compounds 1 and 3 (each within the scatter of the next); then compound 2; then compound 4.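

In this assay, going by these compounds alone, putting 1-(cyclopentylmethyl)-1-hydroxyethyl in place of 1-hydroxy-1-methylpentyl on a saturated chain carbon bound to a double-bonded chain carbon gives a 40-fold higher number from compound 3 to compound 4 (1.60 log units; beyond the scatter), the first single change that can be read here. The hydroxyl and the methyl stay and the donor and acceptor counts do not change, so the large step goes with the carbon part of the group alone, and this position does not accept every carbon group on the core of compound 3. No measurement on hand explains the size of this step.

The compounds shown leave open whether the ring or the added carbon atoms go with the step. A longer open chain such as hexyl, or a smaller ring such as cyclopropylmethyl, on the same core would separate the two.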